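Sulfonyl-substituted quinolinone series: replacing the phenol ring

The compounds below may be only part of what the source reports. "The series", "measured", "known", "first", "only" and "open" are said of these compounds alone.

Two compounds of the shared core have been taken through a functional assay on KOPN-8 cells (Homo sapiens) for antiproliferative activity, with a stated time of 72 h (on this read-out lower numbers stand for an effect already at smaller amounts and higher numbers for an effect only at larger amounts of compound), so far. Compound 1 (`COc1ccc(-c2cc(=O)c3c(OC)cc(OC)cc3n2Cc2ccccc2)cc1`) carries a benzyl group on the ring nitrogen. In this assay compound 1 reaches only the limit > 17300 nM, which is a limit of the assay and not a number. Compound 2 (`COc1ccc(-c2cc(=O)c3c(OC)cc(OC)cc3n2S(=O)(=O)c2cc(Cl)cc(Cl)c2O)cc1`) carries instead a sulfonyl bearing a 3,5-dichloro-2-hydroxyphenyl group. In this assay compound 2 likewise stops at the limit > 37900 nM, again a limit rather than a number. Among the measured compounds shown here, compound 2 thus stands among compounds without a measurable effect: one value sits at the limit of > 17300 nM in this assay, at which 1 of the 2 values shown sits, and the other at the limit of > 37900 nM in this assay, at which 1 of the 2 values shown sits, so no step between measured compounds can be given.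

Compound 3 (`COc1ccc(-c2cc(=O)c3c(OC)cc(OC)cc3n2S(=O)(=O)c2cccc(Br)c2)cc1`) is not yet measured. It differs from compound 2 in one place: 3-bromophenyl in place of 3,5-dichloro-2-hydroxyphenyl on a sulfonyl sulfur. With both measured compounds at limits, no size of step can be read from the series, and the step from compound 2 to compound 3 is expected to be an at least 1.0-fold lower number from compound 2 to compound 3 (0.03 log units; that floor lies within the scatter), no more than the scatter. For compound 3 in this assay the estimate is 35000 nM, within a range of 8000 nM to 100000 nM, most likely again reported as a limit.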

Compound 3, half-maximal effective concentration: > 58600 nM
Compound 3: a limit, no number (the forecaster's own chance of this, stated with the estimate: 75%); middle value at least 1.6-fold (0.22 log units) away from the limit.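

Among the compounds shown here, compound 1, compound 2 and compound 3 all stand at limits and not at numbers, so no step from compound 2 to compound 3 or from compound 1 to compound 3 can be read. The compounds shown leave open whether any group on the ring nitrogen of the shared core gives a measurable effect in this assay.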